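Methoxy on the benzyl ring across two core series

The source may hold more compounds than are shown below. What is called first, only, known or untested is meant among the compounds shown, and "the series" means these compounds.

Compound 1 `CCN(CCCn1sc2cc(OC)c(OC)cc2c1=O)Cc1ccccc1` and compound 2 `CCN(CCCn1sc2cc(OC)c(OC)cc2c1=O)Cc1ccccc1OC` share one core. In an assay on isolated protein for inhibition of Amine oxidase [flavin-containing] A (Homo sapiens), read by fluorescence, with a stated time of 30 min (on this read-out lower numbers stand for stronger inhibition and higher numbers for weaker inhibition), compound 1 gives 9900 nM and compound 2 gives 15500 nM. The change between them, (methoxy in place of hydrogen on an aromatic carbon), made a 1.6-fold higher number from compound 1 to compound 2 (0.19 log units; within the scatter). Compound 3 `COc1cc2sn(CCCCCCN(C)Cc3ccccc3)c(=O)c2cc1OC` carries a different core; the difference between the two cores is not broken down here. In this assay compound 3 gives 23000 nM, which lies within the scatter of the number for compound 2 and beyond the scatter against the number for compound 1. Compound 4 `COc1ccccc1CN(C)CCCCCCn1sc2cc(OC)c(OC)cc2c1=O` is not yet measured. It differs from compound 3 by methoxy in place of hydrogen on an aromatic carbon, the same change as from compound 1 to compound 2, made at the same kind of place. Among the compounds with values here, only one measured instance of this change exists, so the expectation rests on a single pair. Within the data shown here, for compound 4 in this assay a step of a 1.5-fold higher number from compound 3 to compound 4 (0.18 log units; within the scatter) is expected, because a 1.6-fold higher number from compound 1 to compound 2 (0.19 log units; within the scatter) is the only measured instance of this change. Compound 4 is accordingly estimated at 35000 nM, expected between 15000 nM and 80000 nM.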

Compound 4, half-maximal inhibitory concentration: 19900 nM
The estimate for compound 4 lay 1.8-fold (0.25 log units) above the measured number; measured number inside the range.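

In this assay, the change from benzyl to 2-methoxybenzyl on the second core gave a 1.2-fold lower number from compound 3 to compound 4 (0.06 log units; within the scatter). Set beside the earlier step, the change reads alike on the two cores: the same change on two cores in this assay, a 1.6-fold higher number (0.19 log units; within the scatter) from compound 1 to compound 2 and a 1.2-fold lower number (0.06 log units; within the scatter) from compound 3 to compound 4, 1.8-fold (0.26 log units) apart, within the scatter of two such steps. This shows no sign in this assay that the effect of the change depends on the core, but it does not show that the methoxy has any effect on either core, as both steps lie within the scatter, and two pairs are no basis for predicting the step on other cores in the series.

Left open is whether another group in the place of the methoxy, such as fluorine, a hydroxyl or a carboxylic acid, would give a step beyond the scatter on either core. Also open is how the difference between the two cores divides between chain length and the ethyl or methyl on the amine nitrogen, as the compounds shown change both together.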